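Swapping a Substituted Isoxazole for a Pyrazole

The source may report more compounds than this note shows. Statements on the series, on what has been measured and on what is new or still open speak of the compounds shown alone.

Measured compounds:
compound 1 `CCCNCc1cc(-c2c(C(=O)NCC)noc2-c2cc(C(C)C)c(O)cc2O)on1` — "not determined" (no result reported) in a functional assay on A2780 cells (Homo sapiens) for inhibition; on this read-out higher numbers stand for weaker inhibition and lower numbers for stronger inhibition
compound 2 `CCNC(=O)c1noc(-c2cc(C(C)C)c(O)cc2O)c1-c1cc(CN2CCCC2)no1` — 55 nM

Compound 1 carries a 3-((propylamino)methyl)-1,2-oxazol-5-yl group on the shared core. In this assay, from the compounds shown here alone, compound 1 gives "not determined" (no result reported), so it has no single number to stand on and its own potency remains open. Compound 2 , whose core is the same, gives 55 nM in this assay, and that value is the only fixed point available for this series.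

Compound 3 `CCNC(=O)c1noc(-c2cc(C(C)C)c(O)cc2O)c1-c1cn[nH]c1` is the target of the step from compound 1. The change is 1H-pyrazol-4-yl in place of 3-((propylamino)methyl)-1,2-oxazol-5-yl on an aromatic carbon. The group that enters is smaller than the group that leaves.

For the measured compounds named here, no measured step between two compounds of this kind is available, so the size of the effect cannot be read from the data. Given the smaller group, a moderate weakening in this assay seems plausible, though a result within the scatter is also possible. Compound 3 is expected to give about 150 nM, with a likely range from 40 nM to 600 nM.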

Compound 3, half-maximal inhibitory concentration: 38 nM
For compound 3 the middle estimate is 3.9-fold (0.60 log units) above the measured one, outside the stated range (below it).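

In this assay, for the compounds shown here, compound 1 gives "not determined" (no result reported) and so no step to compound 3 can be read from this result. From the compounds shown here alone, how the 3-((propylamino)methyl)-1,2-oxazol-5-yl group of compound 1 compares with the 1H-pyrazol-4-yl group of compound 3 stays open. No evidence shown here accounts for the result of compound 3.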